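Capping an Amine with Acetyl: Expected Effect on Inhibition

This account rests on a few compounds, and the source may have more. Where it says the series, first, only, none or still open, it means among the compounds named here.

Compound 1, with the structure `CCCCc1ccc(CN)c(=O)n1Cc1ccc(-c2ccccc2-c2nn[nH]n2)cc1`, carries a free amine on its core. In a functional assay on the whole organism (artery) for inhibition, with Rattus norvegicus as the target, at a dose of 3 mg/kg by the intraduodenal route (on this read-out higher numbers stand for more inhibition at the one dose given (going by the name of the read-out) and lower numbers for less inhibition), compound 1 gives 2.8%, the lowest of the two numbers in hand. Among the compounds with values here, the only other measured compound, compound 2 with the structure `CCCCc1ccc(CN(Cc2ccccc2)S(=O)(=O)c2ccc(C)cc2)c(=O)n1Cc1ccc(-c2ccccc2-c2nn[nH]n2)cc1`, carries a much larger group on that nitrogen; in this assay compound 2 gives 36.6%, a gap beyond the usual scatter. Within the data shown here, no single-point step between these two is available, so only the two values themselves speak. Compound 3, with the structure `CCCCc1ccc(CNC(C)=O)c(=O)n1Cc1ccc(-c2ccccc2-c2nn[nH]n2)cc1`, differs from compound 1 in one place: acetyl in place of hydrogen on an amine nitrogen. Since compound 1 gives 2.8% while compound 2 gives 36.6%, a substituted nitrogen has been seen to sit beyond the scatter above the free amine, and so a moderate upward step is expected, of size a number 12.2 percentage points higher from compound 1 to compound 3 (beyond the scatter), though it could also stay within the scatter. Compound 3 is estimated at 15%, with a range from 0% to 38%.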

Compound 3, a percentage reported as inhibition, in the whole organism at one dose (the size of the read-out at that dose, not a potency): 8.6%
Compound 3: the middle estimate sits 6.4 percentage points above what was measured; the range from low to high includes it.
By their numbers in this assay, from the lowest: compounds 1 and 3 (each within the scatter of the next); then compound 2.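

In this assay the change to acetyl in place of hydrogen on an amine nitrogen reads as a number 5.8 percentage points higher from compound 1 to compound 3 (within the scatter) and so cannot be told apart from no change. Within the data shown here, this is the first single-place change seen at this nitrogen, and it shows that adding a small acyl group with no ring is not enough on its own to lift the number beyond the scatter at this one dose. Nothing at hand explains this result.

From the compounds shown here alone, it remains open whether an acyl group with a ring, such as benzoyl, or with a longer chain, such as butanoyl, would move the number further at this nitrogen. A plain methyl group or a methanesulfonyl group in the same place would show whether the carbonyl of the acetyl matters for this result.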